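Ethyl for phenyl on the ring nitrogen of compound 2

The compounds below may be only part of what the source reports. "The series", "measured", "known", "first", "only" and "open" are said of these compounds alone.

Two compounds of this series carry a measured number. Compound 1 `CC(C)(C)OC(=O)NCCCCCN1C(Nc2ccc(-c3ccccc3)cc2)=Nc2ccccc2C1CC(=O)NCc1ccccc1` gives 1700 nM in a functional assay on HT-29 cells (Homo sapiens) for inhibition, read by sulforhodamine B assay, with a stated time of 72 h; a lower number here means a stronger inhibitor of growth, a higher number a weaker inhibitor of growth. Compound 2 `O=C(CC1c2ccccc2N=C(N2CCCCC2)N1c1ccccc1)NCc1ccc(NS(=O)(=O)c2ccc(F)cc2)cc1` gives 1710 nM in this assay. Going by the values given here, compound 2 holds the higher of the two numbers, yet its gap to compound 1 lies within the scatter of repeated runs, so the two values show no separation and neither compound can be set above the other. Among the compounds with values here, no step between compounds differing in one place has been measured, so nothing in the data says how far a single change moves the read-out.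

Compound 3 `CCN1C(N2CCCCC2)=Nc2ccccc2C1CC(=O)NCc1ccc(NS(=O)(=O)c2ccc(F)cc2)cc1` is not yet measured. It differs from compound 2 by ethyl in place of phenyl on an amine nitrogen in a ring. Within the data shown here, with no measured step to lean on, the expectation rests on compound 2 alone, whose value 1710 nM is the only anchor, and the step is expected to be modest, most likely toward a somewhat higher number, but possibly none beyond the scatter. Compound 3 is therefore estimated at 2800 nM in this assay, with a range from 900 nM to 9000 nM. The expected step is a 1.6-fold higher number from compound 2 to compound 3 (0.21 log units; within the scatter).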

Compound 3, concentration for 50% growth inhibition: 13900 nM
Estimate against measurement, compound 3: 5.0-fold (0.70 log units) below, and the stated range ends below it.
By their numbers in this assay, from the lowest: compounds 1 and 2 (each within the scatter of the next); then compound 3.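

In this assay, going by these compounds alone, the amine nitrogen in a ring, next to the ring atom that bears a piperidin-1-yl group, is the first position where a single change has a measured size: ethyl in place of phenyl gives an 8.1-fold higher number from compound 2 to compound 3 (0.91 log units; beyond the scatter) with the rest of the molecule unchanged. This position is therefore not indifferent to its substituent, and of this pair, compound 2 with its phenyl is the stronger inhibitor of growth. The change alters both the size of the group and the presence of an aromatic ring, this one pair cannot separate the two, and no measurement here bears on the reason for the step.

Going by these compounds, whether the ring or the size of the group carries the step remains open, and cyclohexyl, benzyl and n-butyl on this nitrogen would each address a different part of that question. Also open, on these data alone, is whether the same step would appear with an amine other than piperidin-1-yl on the neighbouring ring atom, such as morpholin-4-yl.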